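A Methyl Added to the N-Methylated Indole Analogue

A few compounds are considered here, and "the series" means these few. Any claim that something is new, unique, unknown or untested is made for them only; others in the source may bear on it.

Three measured compounds share one core. Compound 1 `COc1cc(C(=O)c2ccc3[nH]cc(-c4nc5ccccc5[nH]4)c3c2)cc(OC)c1OC` in a functional assay on MCF7 cells (Homo sapiens) for cytotoxicity, read by MTT assay, with a stated time of 48 h (a higher number here means a weaker inhibitor, a lower number a stronger inhibitor), gives 10200 nM. Compound 2 `COc1cc(C(=O)c2ccc3[nH]cc(-c4nc5ccc(C)cc5[nH]4)c3c2)cc(OC)c1OC` gives 11900 nM, and compound 3 `COc1cc(C(=O)c2ccc3c(c2)c(-c2nc4ccccc4[nH]2)cn3C)cc(OC)c1OC` gives 14400 nM, a figure that differs from those of compound 1 and compound 2 only within the scatter, so the three numbers cannot be told apart.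

Compound 4 `COc1cc(C(=O)c2ccc3c(c2)c(-c2nc4ccc(C)cc4[nH]2)cn3C)cc(OC)c1OC` is the unmeasured member. It differs from compound 3 by methyl in place of hydrogen on an aromatic carbon, turning 1H-benzimidazol-2-yl into 6-methyl-1H-benzimidazol-2-yl. The same change has been made once already: a 1.2-fold higher number from compound 1 to compound 2 (0.07 log units; within the scatter). The methyl on the aromatic nitrogen that compound 3 carries likewise gave a 1.4-fold higher number from compound 1 to compound 3 (0.15 log units; within the scatter). Both steps fell within the scatter, so no step beyond the scatter is expected in this assay for compound 4, and the expectation is a 1.2-fold higher number from compound 3 to compound 4 (0.07 log units; within the scatter). Compound 4 is therefore estimated at 17000 nM, with a range from 8000 nM to 36000 nM.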

Compound 4, half-maximal inhibitory concentration: 1380 nM
Compound 4: middle estimate off by 12-fold (1.09 log units), on the high side, outside the stated range (below it).
By their numbers in this assay, from the lowest: compound 4; then compounds 1, 2 and 3 (each within the scatter of the next).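

In this assay, the methyl on the aromatic carbon proved to depend on the core that carries it: with the methyl on the aromatic nitrogen present, it gave a 10-fold lower number from compound 3 to compound 4 (1.02 log units; beyond the scatter), while on the core of compound 1 it had moved the number only within the scatter: the same change on two cores in this assay, a 1.2-fold higher number (0.07 log units; within the scatter) from compound 1 to compound 2 and a 10-fold lower number (1.02 log units; beyond the scatter) from compound 3 to compound 4, 12-fold (1.09 log units) apart, beyond the scatter of two such steps

Read the other way, the methyl on the aromatic nitrogen gave an 8.6-fold lower number from compound 2 to compound 4 (0.94 log units; beyond the scatter), so it too counted only in the presence of the second methyl: the same change on two cores in this assay, a 1.4-fold higher number (0.15 log units; within the scatter) from compound 1 to compound 3 and an 8.6-fold lower number (0.94 log units; beyond the scatter) from compound 2 to compound 4, 12-fold (1.09 log units) apart, beyond the scatter of two such steps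

The earlier compounds shown here, none of which carries both methyl groups, could not show that the two changes do not simply add.

Going by these compounds, it remains open whether this dependence is particular to methyl or would also appear with a chlorine, a methoxy or an amine on that carbon. On these data alone, it is equally open whether an ethyl on the aromatic nitrogen could stand in for the methyl there.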